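Growing the para group from isopropyl to tert-butyl

The compounds below may be only part of what the source reports. "The series", "measured", "known", "first", "only" and "open" are said of these compounds alone.

Compound 2, `CC(C)c1ccc(OCC(=O)Nc2ccc(OCC(=O)O)c(F)c2)cc1`, is the weaker of the two compounds measured in a functional assay on CHO cells for agonist activity at Free fatty acid receptor 1 (Homo sapiens), read by FLIPR, tested at 100 nM; on this read-out higher numbers stand for a stronger effect at the one concentration tested and lower numbers for a weaker effect: compound 2 gives 11.8%, whereas compound 1, `Cc1ccc(OCC(=O)Nc2ccc(OCC(=O)O)c(F)c2)cc1`, gives 31.2%. Among the measured compounds shown here, the one measured step that bears on the next change is the one in which isopropyl took the place of methyl on an aromatic carbon, a number 19.4 percentage points lower from compound 1 to compound 2 (beyond the scatter). Compound 3, `CC(C)(C)c1ccc(OCC(=O)Nc2ccc(OCC(=O)O)c(F)c2)cc1`, carries the same kind of change one step further: methyl in place of hydrogen on a saturated chain carbon bound to an aromatic carbon and two saturated chain carbons. Since adding a methyl to this part of compound 1 already lowered the read-out in this assay beyond the scatter, a further methyl at the same spot is expected to lower it again or at best leave it unchanged, giving an estimated step of a number 5.8 percentage points lower from compound 2 to compound 3 (within the scatter). Compound 3 is therefore estimated at 6%, expected to lie between 0% and 20%.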

Compound 3, a percentage reported as activity, at one concentration (the size of the read-out at that concentration, not a potency) in the Free fatty acid receptor 1 assay: 7.65%
Estimate against measurement, compound 3: 1.7 percentage points below, within the range that was stated.
By their numbers in the Free fatty acid receptor 1 assay, from the lowest: compounds 3 and 2 (each within the scatter of the next); then compound 1.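

In the Free fatty acid receptor 1 assay the extra methyl gives a number 4.2 percentage points lower from compound 2 to compound 3 (within the scatter), so isopropyl and tert-butyl cannot be told apart on this read-out. Measured against the smallest group, tert-butyl in place of methyl on the aromatic carbon gives a number 23.6 percentage points lower from compound 1 to compound 3 (beyond the scatter), so among these three compounds only methyl stands apart from the others, while the two branched groups read alike. Nothing available explains why the read-out behaves this way at this position.

Going by these compounds, whether a methoxy group or an amine on that aromatic carbon would match or pass methyl remains open. On these data alone, in a physicochemical assay for lipophilicity, using the shake flask method, at pH 7.4 (on this read-out lower numbers stand for lower lipophilicity and higher numbers for higher lipophilicity), compound 2 is reported as "not determined" (no result reported) and compound 3 as "not determined" (no result reported), so no step can be read for these compounds and how this change acts on that property stays unknown.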